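This account rests on a few compounds, and the source may have more. Where it says the series, first, only, none or still open, it means among the compounds named here.

Measured compounds:
- Compound 1, `Nc1ccc2nccc(SC3(C(=O)O)CCC3)c2c1`, in an assay on HEK293 cells for inhibition of solute carrier family 22 member 12 (Homo sapiens), read by scintillation counting, with a stated time of 12 min (on this read-out higher numbers stand for weaker inhibition and lower numbers for stronger inhibition), compound 1 gives 1790 nM.
- Compound 2, `Cc1ccc2nccc(SC3(C(=O)O)CCC3)c2c1`, in this assay compound 2 gives 343 nM.

Among the measured compounds shown here, compound 2 stands at the lowest number of the two; its only neighbour is compound 1, and the step of a 5.2-fold lower number from compound 1 to compound 2 (0.72 log units; beyond the scatter) lies beyond the scatter. Compound 3, `O=C(O)C1(Sc2ccnc3ccc(-c4ccccc4F)cc23)CCC1`, is not yet measured. It differs from compound 2 by 2-fluorophenyl in place of methyl on an aromatic carbon. For the measured compounds named here, no measured step covers this kind of exchange: the single step that exists, from an amino group to a methyl group at this same position, shows only that this position tolerates a small group and that the number there can move a good deal. For an aromatic ring entering at the same place the data give no direction, so the expected step of a 1.9-fold lower number from compound 2 to compound 3 (0.28 log units; within the scatter) in this assay is drawn wide. Compound 3 is estimated at 180 nM, with a range from 30 nM to 1000 nM.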

Compound 3, half-maximal inhibitory concentration: 333 nM
Compound 3: the middle estimate sits 1.9-fold (0.27 log units) below what was measured; measured number inside the range.
By their numbers in this assay, from the lowest: compounds 3 and 2 (each within the scatter of the next); then compound 1.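

In this assay, putting 2-fluorophenyl in place of methyl gives a 1.0-fold lower number from compound 2 to compound 3 (0.01 log units; within the scatter) and so leaves the number where it was, which shows that this aromatic carbon accepts a whole six-membered aromatic ring as well as a single methyl group. Both groups also keep their distance from the amino group of compound 1, since a 5.4-fold lower number from compound 1 to compound 3 (0.73 log units; beyond the scatter) is a step of about the same size as a 5.2-fold lower number from compound 1 to compound 2 (0.72 log units; beyond the scatter) and lies beyond the scatter in the same direction. No measurement offered here explains why a far larger group changes nothing in this read-out.

The compounds shown leave open what the fluorine contributes, a question that a plain phenyl group at this place would address. They also leave open whether a pyridyl ring or a methoxy group here would keep the number or move it.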